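The compounds below may be only part of what the source reports. "The series", "measured", "known", "first", "only" and "open" are said of these compounds alone.

Of the compounds shown here, three of one series have been tested in an ADME assay on SW480 cells (Homo sapiens) for cytotoxicity, read by MTT assay, with a stated time of 72 h; a lower number here means a stronger inhibitor, a higher number a weaker inhibitor. Compound 1 `CCCCCN1C(=O)C/C(=C\c2cccc(C(=O)Nc3ccc(C)cc3)c2)C1=O` returns only a limit, > 100000 nM. Compound 2 `Cc1ccc(N2C(=O)C/C(=C\c3cccc(C(=O)Nc4cccc(F)c4)c3)C2=O)cc1` gives 96900 nM. Compound 3 `COc1ccc(NC(=O)c2cccc(/C=C3\CC(=O)N(c4ccccc4)C3=O)c2)c(C)c1` also returns only a limit, > 100000 nM; this is the limit of > 100000 nM in this assay, at which 2 of the 3 values shown sit. So compound 3 stands at the edge of what the assay can report, alongside most of the series. Compound 4 `CCOc1ccc(NC(=O)c2cccc(/C=C3\CC(=O)N(c4ccccc4)C3=O)c2)cc1` has not yet been measured; it differs from compound 3 by 4-ethoxyphenyl in place of 4-methoxy-2-methylphenyl on an amide-type nitrogen. For the measured compounds named here, no step between two measured compounds is available to guide this change, and the values so far lie close together. The step of a number no higher from compound 3 to compound 4 (the limit leaves the size open) is expected to be no larger than the usual scatter. Compound 4 is therefore estimated at about 100000 nM, somewhere between 50000 nM and 200000 nM, quite possibly again reported only as a limit.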

Compound 4, half-maximal inhibitory concentration: 91500 nM
The estimate for compound 4 lay 1.1-fold (0.04 log units) above the measured number; measured number inside the range.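

With the same atoms joined differently on an amide-type nitrogen, 4-ethoxyphenyl in place of 4-methoxy-2-methylphenyl gives an at least 1.0-fold lower number from compound 3 to compound 4 (0.03 log units; that floor lies within the scatter) in this assay. This is the only step that can be read at this position, and it shows no change beyond the scatter, though its true size stays open because it rests on a limit: the limit of > 100000 nM in this assay, at which 2 of the 4 values shown sit.

Going by these compounds, what an amine or a carboxylic acid on that phenyl ring would do stays open. So does whether any group at this position can bring the number far down.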